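Adding a Third Chloro to a Trichlorophenyl Styryl Ketone

A few compounds are considered here, and "the series" means these few. Any claim that something is new, unique, unknown or untested is made for them only; others in the source may bear on it.

Compound 2 `COc1ccccc1/C=C(/SCc1ccc(Cl)cc1)C(=O)c1ccc(Cl)cc1` is the starting point. In a functional assay on DU-145 cells (Homo sapiens) for inhibition, read by trypan blue exclusion, with a stated time of 96 h (a lower number here means a stronger inhibitor of growth, a higher number a weaker inhibitor of growth), compound 2 gives 1000 nM. Compound 1 `COc1ccccc1/C=C(/SCc1ccc(Cl)c(Cl)c1)C(=O)c1ccc(Cl)cc1` carries one more chloro group, described as chloro in place of hydrogen on an aromatic carbon, placed ortho to a chloro group and meta to a large group, and the growth inhibition weakens by a 10-fold higher number from compound 2 to compound 1 (1.00 log units; beyond the scatter). In this assay compound 1 gives 10000 nM.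

Compound 3 `O=C(/C(=C\c1cccc(Cl)c1Cl)SCc1ccc(Cl)cc1)c1ccc(Br)cc1` has a different core; the difference between the two cores is not broken down here. In this assay compound 3 gives 10000 nM, level with compound 1 at the digits reported.

Compound 4 `O=C(/C(=C\c1cc(Cl)cc(Cl)c1Cl)SCc1ccc(Cl)cc1)c1ccc(Br)cc1` differs from compound 3 by chloro in place of hydrogen on an aromatic carbon, a change of the same kind as that from compound 2 to compound 1, but here placed meta to a chloro group, meta to a large group and para to a chloro group, on the other ring of the molecule. Because the earlier step was a 10-fold higher number from compound 2 to compound 1 (1.00 log units; beyond the scatter) and compound 3 already gives 10000 nM, the expectation is a step of a 1.5-fold higher number from compound 3 to compound 4 (0.18 log units; within the scatter), a weak or unchanged inhibitor. The estimated value for compound 4 in this assay is 15000 nM, between 5000 nM and 60000 nM.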

Compound 4, concentration for 50% growth inhibition: 1000 nM
Beside the measured number, compound 4's estimate is 15-fold (1.18 log units) above it, and the stated range ends above it.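

In this assay, putting a chloro in place of a hydrogen on an aromatic carbon, which turns the 2,3-dichlorophenyl group into the 2,3,5-trichlorophenyl group, strengthens growth inhibition, with a 10-fold lower number from compound 3 to compound 4 (1.00 log units; beyond the scatter). The same kind of change on another ring of a different core went the opposite way, so its effect does not carry over between these two cores: the same change on two cores in this assay, a 10-fold higher number (1.00 log units; beyond the scatter) from compound 2 to compound 1 and a 10-fold lower number (1.00 log units; beyond the scatter) from compound 3 to compound 4, 100-fold (2.00 log units) apart, beyond the scatter of two such steps. This shows that a step measured on one core is a poor guide to the same kind of step on another core in this series, but it does not show why, since the two steps differ both in the core and in where the chloro sits.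

The compounds shown leave open whether the reversal follows the position of the chloro or the rest of the core, a question that the same placement on both cores could settle. They also leave open how a fluoro, an amine or a carboxylic acid at that place would compare with the chloro.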